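Notes on a stilbene-like series in the cytotoxicity test

The compounds below may be only part of what the source reports. "The series", "measured", "known", "first", "only" and "open" are said of these compounds alone.

Measured so far:
Compound 1, `COc1ccc(-c2nc(/C=C/c3cc4ccccc4nc3OC)no2)cc1`: limit, > 220000 nM
Compound 2, `COc1nc2ccccc2cc1/C=C/c1noc(-c2ccc(F)cc2)n1`: limit, > 230000 nM

In an ADME assay on HepG2 cells (Homo sapiens) for cytotoxicity, read by sulforhodamine B assay, with a stated time of 48 h (on this read-out lower numbers stand for higher toxicity in this test and higher numbers for lower toxicity in this test), compound 1 gives only a limit, > 220000 nM. In the same test compound 2 also gives only a limit, > 230000 nM. Going by the values given here, the one measured step, a step that the two limits leave unreadable from compound 1 to compound 2, cannot be read, since both values sit at limits (the limit of > 220000 nM in this assay, at which 1 of the 2 values shown sits, (the limit of > 230000 nM in this assay, at which 1 of the 2 values shown sits)). Compound 3, `COc1ccccc1-c1nc(/C=C/c2cc3ccccc3nc2OC)no1`, differs from compound 2 by 2-methoxyphenyl in place of 4-fluorophenyl on an aromatic carbon. No measured step bears on this change, and nothing shown points either way. Compound 3 is expected to sit near the limit as well, with a step that the limit leaves unreadable from compound 2 to compound 3 expected to lie within the scatter. The estimate for compound 3 is 250000 nM, ranging from 100000 nM to 500000 nM.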

Compound 3, half-maximal cytotoxic concentration: > 220000 nM
Compound 3: only a limit was reported; the forecaster's own chance of this, stated with the estimate: 80%; the middle value is on the limit's open side.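

Compound 3, like compound 1 and compound 2, gives only a limit in this assay, so no step among these compounds can be read. The compounds shown leave open which change, if any, would give a number rather than a limit in this assay.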